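The source may hold more compounds than are shown below. What is called first, only, known or untested is meant among the compounds shown, and "the series" means these compounds.

Working notes on the series. Going by the values given here, compound 1 `CC(C(=O)NCc1ccc(C(F)(F)F)nc1CCC(C)(C)C)c1ccc(NS(C)(=O)=O)c(F)c1` gives 0.6 nM in an assay on CHO cells for antagonist activity at transient receptor potential cation channel subfamily V member 1 (Homo sapiens), read by FLIPR and calcium flux (a higher number here means a weaker inhibitor, a lower number a stronger inhibitor), which is the highest of the two numbers measured so far. Compound 2 `C[C@H](C(=O)NCc1ccc(C(F)(F)F)nc1C1=CCC(C)(C)CC1)c1ccc(NS(C)(=O)=O)c(F)c1` differs from compound 1 in more than one place; in this assay compound 2 gives 0.1 nM, and the two values lie apart by more than the scatter, with compound 2 showing the lower number. Among the compounds with values here, no single-change step between measured compounds is available, so the pair only shows that a ring-bearing variant of this series has reached a lower number.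

Compound 3 `CC(C(=O)NCc1ccc(C(F)(F)F)nc1/C=C/C1CCCCC1)c1ccc(NS(C)(=O)=O)c(F)c1` has not yet been measured. Relative to compound 1 the change is 2-cyclohexylethenyl in place of 3,3-dimethylbutyl on an aromatic carbon. The incoming group brings a six-membered non-aromatic ring and a double bond outside aromatic rings in place of an open chain, at the aromatic carbon next to the ring nitrogen, ortho to a large group.

For compound 3 the expected step of a 1.5-fold lower number from compound 1 to compound 3 (0.18 log units; within the scatter) is small and toward a lower number, not certainly beyond the scatter, because compound 2 with its ring gives 0.1 nM while compound 1 with the open chain gives 0.6 nM. Compound 3 is therefore estimated at 0.4 nM, with a range from 0.1 nM to 1.5 nM.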

Compound 3, inhibition constant: 0.7 nM
The estimate for compound 3 lay 1.8-fold (0.24 log units) below the measured number, within the range that was stated.
By their numbers in this assay, from the lowest: compound 2; then compounds 1 and 3 (each within the scatter of the next).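

In this assay, placing 2-cyclohexylethenyl in place of 3,3-dimethylbutyl on the aromatic carbon next to the ring nitrogen gives a 1.2-fold higher number from compound 1 to compound 3 (0.07 log units; within the scatter), so compound 1 and compound 3 cannot be told apart at this position. In this single change, an open chain gives way to a six-membered non-aromatic ring of carbon only and a double bond outside aromatic rings without moving the number beyond the scatter, so bringing in such a ring on this carbon is not enough by itself to produce a step that can be read. No measurement in hand bears on why the number stays within the scatter across this change.

As far as these compounds go, it remains open whether the double bond and the ring each matter on their own, which a 2-cyclohexylethyl group on the same carbon would begin to separate from the result for the 2-cyclohexylethenyl group. Also open, from the compounds shown here alone, is how this position responds to a group containing a heteroatom, such as a piperidine or an ether chain, as both groups compared here are made of carbon only.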